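Removing a chloro from a dichlorophenyl bis-curcuminoid pair

A few compounds are considered here, and "the series" means these few. Any claim that something is new, unique, unknown or untested is made for them only; others in the source may bear on it.

Measured compounds:
compound 1, `COc1cc(/C=C/C(=O)C2=C(/C=C/c3ccc(O)c(OC)c3)NC(=O)NC2c2c(Cl)cccc2Cl)ccc1O`, 25000 nM
compound 2, `COc1cc(/C=C/C(=O)C2=C(/C=C/c3ccc(O)c(OC)c3)NC(=O)NC2c2ccccc2Cl)ccc1O`, 100000 nM
compound 3, `COc1cc(/C=C/C(=O)C2=C(/C=C/c3ccc(O)c(OC)c3)NC(=S)NC2c2c(Cl)cccc2Cl)ccc1O`, 100000 nM

In a functional assay on HeLa cells (Homo sapiens) for cytotoxicity, read by MTT assay, with a stated time of 48 h (a higher number here means a weaker inhibitor, a lower number a stronger inhibitor), compound 1 gives 25000 nM. Compound 2 differs from it by hydrogen in place of chloro on an aromatic carbon, and this change gave a 4.0-fold higher number from compound 1 to compound 2 (0.60 log units; beyond the scatter). Compound 3 carries a different core; the difference between the two cores is not broken down here. In this assay compound 3 gives 100000 nM, level with compound 2 at the digits recorded, and the two of them sit at the highest numbers of the three.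

Compound 4, `COc1cc(/C=C/C(=O)C2=C(/C=C/c3ccc(O)c(OC)c3)NC(=S)NC2c2ccccc2Cl)ccc1O`, has not been measured. It stands to compound 3 as compound 2 stands to compound 1: the change is hydrogen in place of chloro on an aromatic carbon, the same change seen between compound 1 and compound 2. For compound 4 the step is expected to be a 1.5-fold higher number from compound 3 to compound 4 (0.18 log units; within the scatter), beside the earlier 4.0-fold higher number from compound 1 to compound 2 (0.60 log units; beyond the scatter), since compound 3 already starts at the weak end with 100000 nM, and a further weakening may be flattened there. The estimate for compound 4 in this assay is therefore 150000 nM, within 60000 nM to 400000 nM.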

Compound 4, half-maximal inhibitory concentration: 50000 nM
For compound 4 the middle estimate is 3.0-fold (0.48 log units) above the measured one; the measured number lies below the stated range.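

In this assay, going from 2,6-dichlorophenyl to 2-chlorophenyl gives a 2.0-fold lower number from compound 3 to compound 4 (0.30 log units; within the scatter), whereas on the other core the same change gave a 4.0-fold higher number from compound 1 to compound 2 (0.60 log units; beyond the scatter). The two steps do not agree: the same change on two cores in this assay, a 4.0-fold higher number (0.60 log units; beyond the scatter) from compound 1 to compound 2 and a 2.0-fold lower number (0.30 log units; within the scatter) from compound 3 to compound 4, 8.0-fold (0.90 log units) apart, beyond the scatter of two such steps. For the compounds shown here, the change therefore does not carry over with a fixed size between these two cores, but with only one pair on each core, this shows neither what in the cores sets the steps apart nor how the change would behave on any further core.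

The aromatic position is varied here only between chloro and hydrogen, so the compounds shown leave open how a fluoro, a methoxy or an amine in that place would behave on either core. Going by these compounds, all four values also come from a single assay, so whether the gap between the two steps would hold in other cells or with another read-out remains open.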